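Replacing the alkyne on the shared core with furan-3-yl

The compounds below may be only part of what the source reports. "The series", "measured", "known", "first", "only" and "open" are said of these compounds alone.

Compound 1 `CCCC#Cc1cc([C@@H]2O[C@H](CO)[C@@H](O)[C@H]2O)n2ncnc(N)c12` gives 1100 nM in a functional assay on K562 cells (Homo sapiens) for antiproliferative activity, with a stated time of 72 h (a higher number here means a weaker inhibitor, a lower number a stronger inhibitor), the lowest of the two numbers available in the series. Compound 3 `Nc1ncnn2c([C@@H]3O[C@H](CO)[C@@H](O)[C@H]3O)cc(-c3ccc(Cl)cc3)c12` gives 47800 nM in this assay. Compound 2 `Nc1ncnn2c([C@@H]3O[C@H](CO)[C@@H](O)[C@H]3O)cc(-c3ccc(F)cc3)c12` reaches only a limit of the assay in this assay, > 100000 nM, and not a number; this is the limit described in the limit of > 100000 nM in this assay, at which 1 of the 3 values shown sits.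

Compound 4 `Nc1ncnn2c([C@@H]3O[C@H](CO)[C@@H](O)[C@H]3O)cc(-c3ccoc3)c12` is not yet measured. It differs from compound 1 in one place: furan-3-yl in place of pent-1-yn-1-yl on an aromatic carbon. Within the data shown here, two measured steps bear on this change, since both also replace pent-1-yn-1-yl on the same aromatic carbon with an aromatic ring: an at least 90-fold higher number from compound 1 to compound 2 (1.95 log units; beyond the scatter) and a 43-fold higher number from compound 1 to compound 3 (1.64 log units; beyond the scatter). The third step, an at least 2.0-fold lower number from compound 2 to compound 3 (0.32 log units; beyond the scatter), concerns only the exchange of the two halogens and does not involve the alkyne. Furan-3-yl is a smaller aromatic ring than either of those, so the rise is expected in the same direction but with wide uncertainty. Compound 4 is therefore estimated at 20000 nM in this assay, between 4000 nM and 100000 nM. The expected step of an 18-fold higher number from compound 1 to compound 4 (1.26 log units; beyond the scatter) would be a large loss, possibly reaching the assay limit.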

Compound 4, half-maximal inhibitory concentration: 2100 nM
The estimate for compound 4 lay 9.5-fold (0.98 log units) above the measured number, outside the stated range (below it).
By their numbers in this assay, from the lowest: compounds 1 and 4 (each within the scatter of the next); then compound 3. At a limit, above all of these: compound 2.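

Furan-3-yl and pent-1-yn-1-yl cannot be told apart on this aromatic carbon in this assay, with a 1.9-fold higher number from compound 1 to compound 4 (0.28 log units; within the scatter), so an aromatic ring here does not in itself carry the loss seen with the two halogenated phenyl groups. The large gaps lie between the aromatic groups themselves, with a 23-fold lower number from compound 3 to compound 4 (1.36 log units; beyond the scatter) and an at least 47-fold lower number from compound 2 to compound 4 (1.67 log units; beyond the scatter). The second of these steps is only a bound, since compound 2 stands at a limit of the assay and not at a number: the limit of > 100000 nM in this assay, at which 1 of the 4 values shown sits.

The values do not show whether the gap goes with the phenyl ring or with its halogen, and unsubstituted phenyl would separate the two. As far as these compounds go, how far this position tolerates other groups, such as thiophen-3-yl, an amine or a longer alkyne chain, also remains open.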